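Compound 1 and the Step to Compound 4

This account rests on a few compounds, and the source may have more. Where it says the series, first, only, none or still open, it means among the compounds named here.

Three compounds with a shared core have numbers in a physicochemical assay for solubility, at pH 7.4; on this read-out lower numbers stand for lower solubility and higher numbers for higher solubility. Compound 1 (`O=C(N[C@H]1CN(S(=O)(=O)c2ccccc2)C[C@@H]1C(=O)N[C@H]1CCCNC1)c1cn(C2CC2)cn1`) gives 664000 nM as the highest of the three. Compound 2 (`Cc1nc(-c2cccc(C(F)(F)F)c2)sc1C(=O)N[C@H]1CN(S(=O)(=O)c2ccccc2)C[C@@H]1C(=O)N[C@H]1CCCNC1`) gives 112000 nM and compound 3 (`Cc1oc(-c2ccc(C(F)(F)F)cc2)nc1C(=O)N[C@H]1CN(S(=O)(=O)c2ccccc2)C[C@@H]1C(=O)N[C@H]1CCCNC1`) gives 13000 nM in the same measurement, and both numbers lie lower than that of compound 1 by more than the usual scatter.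

Compound 4 (`O=C(N[C@H]1CN(S(=O)(=O)c2ccccc2)C[C@@H]1C(=O)N[C@H]1CCCNC1)c1cc(-c2ccc(Cl)cc2)on1`) has not yet been measured. It differs from compound 1 in one place, with 5-(4-chlorophenyl)-1,2-oxazol-3-yl in place of 1-cyclopropyl-1H-imidazol-4-yl on a carbonyl carbon.

Within the data shown here, no measured pair differs in only one place, so the expectation rests on a comparison of the three values alone. Like compound 4, compound 2 at 112000 nM and compound 3 at 13000 nM hold a six-membered aromatic ring of carbon only in the group on that carbonyl carbon, whereas compound 1 does not. A fall beyond the scatter is therefore expected in this assay, and the estimate is a step of a 19-fold lower number from compound 1 to compound 4 (1.28 log units; beyond the scatter) in that direction. Compound 4 is expected to read 35000 nM (estimated range 9000 nM to 130000 nM).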

Compound 4, solubility: 12000 nM
For compound 4 the middle estimate is 2.9-fold (0.46 log units) above the measured one; low and high end bracket the measured number.
By their numbers in this assay, from the lowest: compounds 4 and 3 (each within the scatter of the next); then compound 2; then compound 1.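

Among these compounds, the exchange of 1-cyclopropyl-1H-imidazol-4-yl for 5-(4-chlorophenyl)-1,2-oxazol-3-yl on a carbonyl carbon gives the first reading in which only one place changes, and this assay shows a 55-fold lower number from compound 1 to compound 4 (1.74 log units; beyond the scatter), a large step. The earlier compounds shown here could not show this, as none of them formed a pair differing in one place, so the size of a change at this position can now be read with the rest of the molecule held constant. Nothing measured here accounts for the step, and it cannot be divided among the loss of the three-membered ring of carbon only, the entry of the six-membered aromatic ring of carbon only, the chlorine and the exchange of one five-membered aromatic ring for another.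

Going by these compounds, it remains open how this assay would respond to an amine or a carboxylic acid in place of the chlorine, or to a longer chain in place of the cyclopropyl group. Also open, on these data alone, is where the reading would stand with a 1,2-oxazol-3-yl group that carries only a methyl group, which would show how much of the step stays without the six-membered aromatic ring.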